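A few compounds are considered here, and "the series" means these few. Any claim that something is new, unique, unknown or untested is made for them only; others in the source may bear on it.

Of the compounds shown here, two built on a shared core have so far been tested in a functional assay on CCRF-CEM cells (Homo sapiens) for cytotoxicity, with a stated time of 72 h; on this read-out higher numbers stand for weaker inhibition and lower numbers for stronger inhibition. Compound 1 `O=C1/C(=C/c2ccc(Cl)cc2)CCC/C1=C\c1ccc([N+](=O)[O-])cc1` gives 8180 nM in this assay. Compound 2 `O=C1/C(=C/c2ccc(Cl)cc2)CCC/C1=C\c1cccc([N+](=O)[O-])c1` gives 1750 nM in this assay. Of these two numbers, compound 1 stands at the higher one, which here means the weaker inhibition, and the gap to compound 2 lies beyond the usual scatter, so compound 2 is the stronger inhibitor of the pair. For compound 1 and compound 2 no step has been worked out; only their two values are shown.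

The next compound, compound 3 `COc1ccc(/C=C2\CCC/C(=C\c3ccc([N+](=O)[O-])cc3)C2=O)cc1`, keeps the core of compound 1 and carries one change: methoxy in place of chloro on an aromatic carbon. Going by the values given here, no measured pair shows this exact exchange, so the size of the step can only be estimated. Methoxy in place of chloro on an aromatic carbon is expected to leave the number close to where compound 1 stands, with a step of a 1.2-fold higher number from compound 1 to compound 3 (0.06 log units; within the scatter) that is estimated to stay within the scatter, leaning if anything toward weaker inhibition. Compound 3 is therefore expected to give about 9500 nM in this assay, within a range from 3000 nM to 30000 nM.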

Compound 3, half-maximal inhibitory concentration: 250000 nM
Compound 3: middle estimate off by 26-fold (1.42 log units), on the low side; the measured number lies above the stated range.
By their numbers in this assay, from the lowest: compound 2; then compound 1; then compound 3.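

In this assay, the exchange of 4-chlorophenyl for 4-methoxyphenyl turns out to be a large change, with a 31-fold higher number from compound 1 to compound 3 (1.49 log units; beyond the scatter). At this position, then, replacing the single chlorine with methoxy, which has two heavy atoms and one hydrogen-bond acceptor, is enough to shift the number far toward weaker inhibition, so the two groups are not interchangeable here. Nothing available explains why the step is so large, and its cause remains unknown.

Going by these compounds alone, with only this one exchange at this position, it remains open whether the large step goes with the loss of the chlorine, the arrival of the oxygen, or the extra carbon, and a hydroxyl, a methyl or a fluoro group on the same aromatic carbon would help separate these possibilities. Going by these compounds, it is also open whether methoxy in place of chloro would give a step of similar size on the core of compound 2.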